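The source may report more compounds than this note shows. Statements on the series, on what has been measured and on what is new or still open speak of the compounds shown alone.

Compound 3 `Cc1cc(Oc2ccccc2Cl)c(S(C)(=O)=O)cc1C(=O)N=C(N)N` gives 14 nM in a functional assay for inhibition of sodium/hydrogen exchanger (Oryctolagus cuniculus); a higher number here means a weaker inhibitor, a lower number a stronger inhibitor. For the measured compounds named here, that is the lowest of the three numbers measured so far, yet its neighbours lie close: compound 1 `Cc1cc(Cl)c(S(C)(=O)=O)cc1C(=O)N=C(N)N` gives 25 nM and compound 2 `Cc1cc(OCc2ccccc2)c(S(C)(=O)=O)cc1C(=O)N=C(N)N` gives 28 nM, and the steps of a 1.8-fold lower number from compound 1 to compound 3 (0.25 log units; within the scatter) and a 2.0-fold lower number from compound 2 to compound 3 (0.30 log units; within the scatter) both sit within the scatter, so no compound can be called the strongest. Compound 4 `Cc1cc(Nc2cccc(Cl)c2)c(S(C)(=O)=O)cc1C(=O)N=C(N)N` has not been measured; it differs from compound 3 by (3-chlorophenyl)amino in place of 2-chlorophenoxy on an aromatic carbon. The earlier swaps at this aromatic carbon, from chloro to benzyloxy a 1.1-fold higher number from compound 1 to compound 2 (0.05 log units; within the scatter) and from chloro to 2-chlorophenoxy, moved the number little, so another swap there is expected to give no step beyond the scatter, a 1.4-fold higher number from compound 3 to compound 4 (0.15 log units; within the scatter). Compound 4 is therefore estimated at 20 nM, with a range from 8 nM to 50 nM.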

Compound 4, half-maximal inhibitory concentration: 33 nM
Beside the measured number, compound 4's estimate is 1.7-fold (0.22 log units) below it; the measured number falls inside the stated range.
By their numbers in this assay, from the lowest: compounds 3, 1, 2 and 4 (each within the scatter of the next, the first and the last beyond it).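

The step of a 2.4-fold higher number from compound 3 to compound 4 (0.37 log units; beyond the scatter) is the only one at this aromatic carbon that lies beyond the scatter, so in this assay this exchange of 2-chlorophenoxy for (3-chlorophenyl)amino is a real, if modest, change. The steps of a 1.2-fold higher number from compound 2 to compound 4 (0.07 log units; within the scatter) and a 1.3-fold higher number from compound 1 to compound 4 (0.12 log units; within the scatter) stay within the scatter, so chloro, benzyloxy and (3-chlorophenyl)amino cannot be told apart here. No evidence on hand accounts for the step.

This swap alters both the linking atom and the chlorine's place on the ring, and the compounds shown cannot separate the two. On these data alone, what a simple amine or a carboxylic acid would do at this carbon also stays open.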